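A Methyl on the Amino Group of Compound 3

The compounds below may be only part of what the source reports. "The series", "measured", "known", "first", "only" and "open" are said of these compounds alone.

In an ADME assay on the whole organism (strain Balb) for pharmacokinetics, with Mus musculus as the target, read by LC-MS, at a dose of 10 mg/kg by the intravenous route (on this read-out higher numbers stand for fast clearance and lower numbers for slow clearance), compound 1 (`CCc1ccc(Cl)cc1-n1cc(-c2ncnn3cccc23)cc1C(N)=O`) stands at 51 mL/min/kg while compound 2 (`Cc1ccc(Cl)cc1-c1cc(-c2ncnc3[nH]ccc23)[nH]c1C(N)=O`) carries the entry "not determined" (no result reported) and offers no number to compare. Compound 3 (`CCc1ccc(Cl)cc1-n1cc(-c2cc(N)ncn2)cc1C(N)=O`) reads 8.3 mL/min/kg and is the lowest of the two numbers, beyond the scatter from compound 1. Compound 4 (`CCc1ccc(Cl)cc1-n1cc(-c2cc(NC)ncn2)cc1C(N)=O`) has methyl in place of hydrogen on a nitrogen on an aromatic ring, amino to methylamino (methyl in place of hydrogen on a nitrogen on an aromatic ring). Among the measured compounds shown here, no measured pair differs in one place, so the expectation rests on this change alone: a modest rise in this assay that may stay close to the scatter. The expected step is a 1.7-fold higher number from compound 3 to compound 4 (0.23 log units; within the scatter) by this estimate. Compound 4 is estimated at 14 mL/min/kg with 6 mL/min/kg to 32 mL/min/kg as the expected range.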

Compound 4, clearance in the Mus musculus assay: 12 mL/min/kg
For compound 4 the middle estimate is 1.2-fold (0.07 log units) above the measured one; the measured number falls inside the stated range.
By their numbers in the Mus musculus assay, from the lowest: compounds 3 and 4 (each within the scatter of the next); then compound 1.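

In the Mus musculus assay compound 3 gives 8.3 mL/min/kg and compound 4 gives 12 mL/min/kg, and the amino to methylamino change on this nitrogen reads a 1.4-fold higher number from compound 3 to compound 4 (0.16 log units; within the scatter) and so gives the first direct test at this position, where the two compounds cannot be told apart. In a physicochemical assay for solubility, at pH 7 (a lower number here means a less soluble compound, a higher number a more soluble compound), compound 3 gives 128000 nM and compound 4 gives 111000 nM, and the same change reads a 1.2-fold lower number from compound 3 to compound 4 (0.06 log units; within the scatter) and again does not separate them, so this nitrogen tolerates a methyl in place of hydrogen in both assays. Nothing available explains either result. Still open, as far as these compounds go, is whether a longer chain such as propyl on this nitrogen, or a morpholine in place of the amino group, would also leave both assays unmoved.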